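Chloro for fluoro on the aryl ring of compound 2

The source may report more compounds than this note shows. Statements on the series, on what has been measured and on what is new or still open speak of the compounds shown alone.

Compound 1 `Cn1ncc2c(NC(=O)NCc3cc(C(F)(F)F)nn3-c3cccc(Cl)c3)cccc21`: 2.3 nM
Compound 2 `Cn1ncc2c(NC(=O)NCc3cc(C(F)(F)F)nn3-c3ccc(F)c(F)c3)cccc21`: 4.9 nM

Two analogues sharing one core have been measured in an assay on CHO-K1 cells for antagonist activity at transient receptor potential cation channel subfamily V member 1 (Homo sapiens), read by FLIPR and calcium flux, with a stated time of 6 min; on this read-out lower numbers stand for stronger inhibition and higher numbers for weaker inhibition. Compound 1 gives 2.3 nM, and compound 2 gives 4.9 nM. Between them lies one step, a 2.1-fold higher number from compound 1 to compound 2 (0.33 log units; beyond the scatter), so compound 2 stands at the higher of the two numbers.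

Compound 3 `Cn1ncc2c(NC(=O)NCc3cc(C(F)(F)F)nn3-c3ccc(F)c(Cl)c3)cccc21` differs from compound 2 by chloro in place of fluoro on an aromatic carbon. Among the measured compounds shown here, the only step measured so far that bears on this change is a 2.1-fold higher number from compound 1 to compound 2 (0.33 log units; beyond the scatter), which exchanged the whole aryl ring and was modest. Compound 3 returns a chloro group to the ring while keeping the second fluoro, so a small move back toward compound 1 is expected, perhaps within the scatter. For compound 3 in this assay the expected number is 2.8 nM, with a range of 1.2 nM to 6.5 nM, a step of a 1.8-fold lower number from compound 2 to compound 3 (0.24 log units; within the scatter).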

Compound 3, inhibition constant: 1.9 nM
Beside the measured number, compound 3's estimate is 1.5-fold (0.17 log units) above it; the range from low to high includes it.
By their numbers in this assay, from the lowest: compounds 3 and 1 (each within the scatter of the next); then compound 2.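

In this assay this position responds to a change of one atom for one atom: chloro in place of fluoro, ortho to a fluoro group and meta to a large group, gives a 2.6-fold lower number from compound 2 to compound 3 (0.41 log units; beyond the scatter) and so reaches a size that compound 1 and compound 2 had shown only across a whole change of aryl ring. Fluoro in place of hydrogen on the chlorinated ring gives a 1.2-fold lower number from compound 1 to compound 3 (0.08 log units; within the scatter) and so leaves compound 1 and compound 3 level on this read-out. Among these three compounds, the two carrying chloro stand together, while compound 2, with fluoro at this position, has the higher number. No measurement at hand explains these steps.

From the compounds shown here alone, whether bromo, methyl or trifluoromethyl at this position would match chloro remains open. So does the effect of a methoxy group or an amine there.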